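Compound 3 to compound 4: a step from a limit

The source may hold more compounds than are shown below. What is called first, only, known or untested is meant among the compounds shown, and "the series" means these compounds.

Values in an ADME assay on cells (Fibroblast, Gallus gallus) for cytotoxicity, read by CCK-8 assay, with a stated time of 48 h (on this read-out lower numbers stand for higher toxicity in this test and higher numbers for lower toxicity in this test), measured so far
Compound 1 `CCC(CC)O[C@@H]1C=C(C(=O)O)C[C@H](NCc2ccc(C(C)(C)C)cc2)[C@H]1NC(C)=O` gives > 200000 nM
Compound 2 `CCC(CC)Oc1ccc(CN[C@H]2CC(C(=O)O)=C[C@@H](OC(CC)CC)[C@@H]2NC(C)=O)cc1` gives > 200000 nM
Compound 3 `CCC(CC)O[C@@H]1C=C(C(=O)O)C[C@H](NCc2ccc(SC3CCCC3)cc2)[C@H]1NC(C)=O` gives > 200000 nM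

Each of these values is a limit and not a number. Compound 3 therefore holds only the limit > 200000 nM and no exact value. Compound 4 `CCC(CC)O[C@@H]1C=C(C(=O)O)C[C@H](NCc2ccc(C(=O)c3ccccc3)cc2)[C@H]1NC(C)=O` brings benzoyl in place of cyclopentylsulfanyl on an aromatic carbon. Two measured swaps on that aromatic carbon bear on it (a step that the two limits leave unreadable from compound 1 to compound 3) and (a step that the two limits leave unreadable from compound 2 to compound 3), but neither has a readable size. Among the measured compounds shown here, the only guide is the shared ceiling (the limit of > 200000 nM in this assay, at which 3 of the 3 values shown sit) and it shows no direction. The expected step in this assay is none beyond the scatter (a number no higher from compound 3 to compound 4 (the limit leaves the size open)) with no direction foreseen. Compound 4 is estimated at 200000 nM with an expected range from 100000 nM to 400000 nM and will probably be reported as a limit again.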

Compound 4, half-maximal cytotoxic concentration: > 200000 nM
Compound 4 was reported as a limit; the forecaster's own chance of this, stated with the estimate: 85%; the middle value sits exactly at the limit.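

Among the compounds shown here, no step from compound 1, compound 2 or compound 3 to compound 4 can be read, because all four values are limits and not numbers: the limit of > 200000 nM in this assay, at which 4 of the 4 values shown sit. The compounds shown leave open whether swapping these groups on the aromatic carbon changes the value at all.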